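The compounds below may be only part of what the source reports. "The series", "measured", "known", "first", "only" and "open" are said of these compounds alone.

Measured so far in a physicochemical assay for solubility, at pH 7.4; on this read-out lower numbers stand for lower solubility and higher numbers for higher solubility:

Compound 1 `Cc1cc(C)c(-c2nc3ccccc3[nH]2)cc1NC(=O)c1ccc(OCc2ccccn2)cc1` — compound 1 gives < 1000 nM, which is a limit of the assay rather than a number.
Compound 2 `Cc1cc(C)c(-c2c[nH]nc2C)cc1NC(=O)c1ccc(OCc2ccccn2)cc1` — compound 2 gives 33000 nM.
Compound 3 `Cc1cc(C)c(-c2ccc(N)cn2)cc1NC(=O)c1ccc(OCc2ccccn2)cc1` — compound 3 gives < 1000 nM, again a limit of the assay and not a number.

Compound 3 therefore stands at the lower edge of what this assay can report, at the limit of < 1000 nM in this assay, at which 2 of the 3 values shown sit. Of the two steps that lead to it, an at least 33-fold lower number from compound 2 to compound 3 (1.51 log units; beyond the scatter) is large, while a step that the two limits leave unreadable from compound 1 to compound 3 cannot be read, since both ends are limits.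

Compound 4 `Cc1cc(C)c(-c2ccc(N)nn2)cc1NC(=O)c1ccc(OCc2ccccn2)cc1` is the next compound to be measured. It differs from compound 3 in one place: 6-aminopyridazin-3-yl in place of 5-aminopyridin-2-yl on an aromatic carbon. Going by the values given here, none of the measured steps makes a change of this kind; each of them swaps one whole ring for a different ring, whereas here the ring keeps its size and its amino group and only exchanges one ring carbon for a ring nitrogen. The measured steps thus give no direct guide, and the expectation is a step of an at least 1.5-fold higher number from compound 3 to compound 4 (0.17 log units; that floor lies within the scatter) in this assay, most likely within the scatter. Compound 4 is estimated at 1500 nM, with a range from 400 nM to 6000 nM.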

Compound 4, solubility: 6000 nM
Compound 4: the middle estimate sits 4.0-fold (0.60 log units) below what was measured, and the stated range covers the measured number.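

In this assay, going by these compounds alone, the ring at this position keeps its size and its amino group and exchanges only one ring carbon for a ring nitrogen, and this single exchange gives an at least 6.0-fold higher number from compound 3 to compound 4 (0.77 log units; beyond the scatter). That step is only a floor, as is an at least 6.0-fold higher number from compound 1 to compound 4 (0.77 log units; beyond the scatter), since compound 1 and compound 3 each sit at a limit of the assay rather than at a number: the limit of < 1000 nM in this assay, at which 2 of the 4 values shown sit. The 3-methyl-1H-pyrazol-4-yl group of compound 2 is therefore no longer the only group shown at this position that gives a value clear of that limit, although the 6-aminopyridazin-3-yl group does not match it, with a 5.5-fold lower number from compound 2 to compound 4 (0.74 log units; beyond the scatter).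

The compounds shown leave open how much the amino group contributes to this result, which a methoxy or a dimethylamino group in its place on the same ring would help to settle. From the compounds shown here alone, it also remains open whether a second ring nitrogen placed elsewhere in the ring would give a step of similar size, or whether the same exchange would carry over to the ring of compound 1.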